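Swapping a Fused Ring for Methyltetrazole on a Ketone

This account rests on a few compounds, and the source may have more. Where it says the series, first, only, none or still open, it means among the compounds named here.

Compound 1, `CCCCCCCC/C=C\CCCCCCC(=O)c1nc2cnccc2o1`, was tested in an assay on isolated protein for inhibition of Fatty-acid amide hydrolase 1 (Homo sapiens) (a lower number here means a stronger inhibitor, a higher number a weaker inhibitor), and gave 7.2 nM. Of the two numbers recorded, this is the higher one. Compound 2, `O=C(CCCCc1ccccc1)c1nc2ncccc2o1`, gave the lower number, 0.3 nM. Compound 3, `CCCCCCCC/C=C\CCCCCCC(=O)c1nc(-c2ccccc2)c(-c2ccccc2)o1`, returned only a limit of the assay, > 100000 nM, not a number; this is the limit of > 100000 nM in this assay, at which 1 of the 3 values shown sits.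

Compound 4, `CCCCCCCC/C=C\CCCCCCC(=O)c1nnn(C)n1`, is not yet measured. It differs from compound 1 in one place: a group of 6 heavy atoms (2 carbon, 4 nitrogen; one five-membered aromatic ring with 4 hetero atoms) in place of a group of 9 heavy atoms (6 carbon, 2 nitrogen, 1 oxygen; one five-membered aromatic ring with 2 hetero atoms, one six-membered aromatic ring with 1 hetero atom), on a carbonyl carbon. The long unsaturated chain and the carbonyl stay the same; only the aromatic part attached to the carbonyl carbon is exchanged.

For the measured compounds named here, no measured pair here shows the effect of such an exchange, so the expectation rests on the shared chain of compound 1 and its value 7.2 nM. The step from compound 1 to compound 4 is expected to be a 28-fold higher number from compound 1 to compound 4 (1.44 log units; beyond the scatter), toward a weaker inhibitor, beyond the scatter. For compound 4 the estimated value is 200 nM, with a range from 30 nM to 2000 nM.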

Compound 4, inhibition constant: 65 nM
Estimate against measurement, compound 4: 3.1-fold (0.49 log units) above; measured number inside the range.
By their numbers in this assay, from the lowest: compound 2; then compound 1; then compound 4. At a limit, above all of these: compound 3.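

The exchange to 2-methyl-2H-tetrazol-5-yl on the carbonyl carbon gives a 9.0-fold higher number from compound 1 to compound 4 (0.96 log units; beyond the scatter) in this assay as a modest step toward a weaker inhibitor. For the compounds shown here, with the long unsaturated chain held fixed, this is the first measured step at this position, and it shows that the two-ring group of compound 1 is not essential: a single five-membered aromatic ring with 4 hetero atoms, in a smaller group, still leaves compound 4 a nanomolar inhibitor. Nothing measured here explains why inhibition weakens with this exchange.

Still open, from the compounds shown here alone, is whether the methyl on the tetrazole matters, as an ethyl group or a plain hydrogen in its place would show. Also open, going by these compounds, is whether the same exchange would cost as much on the phenyl-ended chain of compound 2.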